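Replacing Dichlorophenyl with Dimethoxyphenyl on the Benzylamine Arm

The source may hold more compounds than are shown below. What is called first, only, known or untested is meant among the compounds shown, and "the series" means these compounds.

Three compounds share one core and differ only in the group hanging from it. Compound 1 `Nc1cc(N)c2nc(-c3ccccc3)c(Oc3ccc(Cl)c(Cl)c3)nc2c1` is measured in a functional assay on HCT-15 cells (Homo sapiens) for inhibition, read by sulforhodamine B assay, with a stated time of 48 h (on this read-out lower numbers stand for stronger inhibition of growth and higher numbers for weaker inhibition of growth), where compound 1 gives 20000 nM. Compound 3 `Nc1cc(N)c2nc(-c3ccccc3)c(Sc3ccc(F)cc3)nc2c1` gives 13500 nM, and the change a 1.5-fold lower number from compound 1 to compound 3 (0.17 log units; within the scatter) exchanges both the linking atom and the ring substituents without moving the number beyond the scatter. Compound 2 `Nc1cc(N)c2nc(-c3ccccc3)c(NCc3ccc(Cl)c(Cl)c3)nc2c1` gives 4680 nM, the lowest of the three; its nearest neighbour is compound 3 and its furthest is compound 1, and both of those gaps lie beyond the scatter.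

Compound 4 `COc1ccc(CNc2nc3cc(N)cc(N)c3nc2-c2ccccc2)cc1OC` is the next step from compound 2: 3,4-dimethoxyphenyl in place of 3,4-dichlorophenyl on a saturated chain carbon bound to a nitrogen on an aromatic ring. Among the measured compounds shown here, no measured step swaps a chlorine pair for a methoxy pair on the same ring, so the only guide is the step from compound 1 to compound 3, which changed the aryl substituents together with the linker and stayed within the scatter. The step from compound 2 to compound 4 is therefore expected to be modest, and a slightly higher number is the more likely outcome, expressed as a 1.7-fold higher number from compound 2 to compound 4 (0.23 log units; within the scatter). Compound 4 is estimated at 8000 nM, with a range from 3000 nM to 25000 nM.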

Compound 4, concentration for 50% growth inhibition: 30200 nM
For compound 4 the middle estimate is 3.8-fold (0.58 log units) below the measured one, outside the stated range (above it).
By their numbers in this assay, from the lowest: compound 2; then compounds 3, 1 and 4 (each within the scatter of the next, the first and the last beyond it).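

In this assay, the substituents on the aryl group at this place, a saturated chain carbon bound to a nitrogen on an aromatic ring, clearly matter: the change gives a 6.5-fold higher number from compound 2 to compound 4 (0.81 log units; beyond the scatter) and is the first listed step to alter those substituents while the linker stays the same. Among the compounds shown here, the only earlier step, a 1.5-fold lower number from compound 1 to compound 3 (0.17 log units; within the scatter) changed the linker and the ring substituents together, so it could not show what the substituents do alone, and it gave no sign of a change of this size. The entering 3,4-dimethoxyphenyl has 10 heavy atoms and 2 hydrogen-bond acceptors, against 8 and 0 for 3,4-dichlorophenyl, but no measurement shown ties the higher number to either difference or to any other feature of the groups.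

The compounds shown leave open whether the shift comes from removing the chlorines, adding the methoxy groups, or both together. They also leave open how this ring would read with a single chlorine, a single methoxy, a hydroxyl or an amine in the same positions.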